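Trading chloro for trifluoromethyl on compound 1

A few compounds are considered here, and "the series" means these few. Any claim that something is new, unique, unknown or untested is made for them only; others in the source may bear on it.

For the measured compounds named here, in an ADME assay on L6 cells (Rattus norvegicus) for cytotoxicity, read by resazurin assay, with a stated time of 72 h (on this read-out lower numbers stand for stronger inhibition and higher numbers for weaker inhibition), compound 1 `OC(c1ccc(Cl)cc1)(c1ccc(Cl)cc1)c1cncnc1` gives 47200 nM, the only true number among the compounds measured so far. Compound 2 `OC(c1ccc(Cl)cc1)(c1cncnc1)c1ccccc1F` reports > 100000 nM, which is a limit of the test and not a number. Compound 3 `OC(c1ccc(Cl)cc1)(c1cncnc1)c1cccc(F)c1` reports > 100000 nM, which is also a limit.

Compound 4 `OC(c1ccc(Cl)cc1)(c1ccc(C(F)(F)F)cc1)c1cncnc1` is compound 1 with a single change: trifluoromethyl in place of chloro on an aromatic carbon. Trifluoromethyl takes the place of chloro on an aromatic carbon of a six-membered aromatic ring of carbon only, para to a large group.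

Going by the values given here, two measured steps bear on this ring, though both replace the whole 4-chlorophenyl. Changing it to 2-fluorophenyl gives an at least 2.1-fold higher number from compound 1 to compound 2 (0.32 log units; beyond the scatter), and changing it to 3-fluorophenyl gives an at least 2.1-fold higher number from compound 1 to compound 3 (0.32 log units; beyond the scatter). As far as these compounds go, both lie beyond the scatter, but their true sizes remain unknown, and neither step tests trifluoromethyl. Compound 4 differs from those two by keeping a group in the place that chloro held, so only a weak guide carries over, and no clear direction follows from it. The expected result in this assay is a 1.0-fold lower number from compound 1 to compound 4 (0.02 log units; within the scatter), with no change beyond the scatter as the best guess. For compound 4 the estimate is 45000 nM, with an expected range of 18000 nM to 100000 nM.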

Compound 4, half-maximal inhibitory concentration: 66800 nM
Compound 4: the middle estimate sits 1.5-fold (0.17 log units) below what was measured, and the stated range covers the measured number.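

In this assay, replacing chloro with trifluoromethyl gives a 1.4-fold higher number from compound 1 to compound 4 (0.15 log units; within the scatter), so this position takes a group of 4 heavy atoms in place of 1 without a change that can be told from the scatter. For the compounds shown here, the earlier steps replaced the whole 4-chlorophenyl and ended at a limit of the test, whereas this one changes only the group on the ring and gives a true number at both ends, making it the first step here whose size can be read. On the evidence of this single pair, chloro and trifluoromethyl cannot be told apart on this read-out, which is too little to support a wider rule.

Still open, as far as these compounds go, is whether a different kind of group in this place, such as an amine, a carboxylic acid or a longer chain, would move the number beyond the scatter in either direction. A move towards weaker inhibition would also be hard to size, because the test runs out not far above the true numbers seen so far: the limit of > 100000 nM in this assay, at which 2 of the 4 values shown sit.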